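The compounds below may be only part of what the source reports. "The series", "measured", "known", "first", "only" and "open" are said of these compounds alone.

Compound 1 `CCC(C)C(=O)Nc1c(C(O)(C(F)(F)F)C(F)(F)F)ccc2ccccc12` carries a sec-butyl on the amide carbonyl carbon of the shared core. Among the measured compounds shown here, in an assay on LtK cells with ATP-sensitive inward rectifier potassium channel 11 (Homo sapiens) as the target (on this read-out lower numbers stand for an effect already at smaller amounts and higher numbers for an effect only at larger amounts of compound), compound 1 gives 177000 nM, the only full number obtained so far in this assay. Compound 2 `CCCC(C)C(=O)Nc1c(C(O)(C(F)(F)F)C(F)(F)F)ccc2ccccc12` is reported in this assay only as a limit, > 10000 nM, not as a number. The measured step that the limit leaves unreadable from compound 1 to compound 2 cannot be sized because of the limit of > 10000 nM in this assay, at which 1 of the 2 values shown sits. Compound 3 `O=C(CCc1ccccc1)Nc1c(C(O)(C(F)(F)F)C(F)(F)F)ccc2ccccc12` has not yet been measured in this assay; it differs from compound 1 by phenethyl in place of sec-butyl on a carbonyl carbon. For the measured compounds named here, no measured step follows an exchange of sec-butyl for phenethyl, and the single measured step, methyl in place of hydrogen on a saturated chain carbon, ends at a limit and gives no size. Compound 1 stands at a weak value, and compound 3 is expected to stay in the same weak region, with a step of a 1.5-fold lower number from compound 1 to compound 3 (0.17 log units; within the scatter) not expected to exceed the scatter. The estimate for compound 3 is 120000 nM, from 20000 nM to 600000 nM.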

Compound 3, half-maximal effective concentration: 1750 nM
Estimate against measurement, compound 3: 69-fold (1.84 log units) above, and the stated range ends above it.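

Phenethyl in place of sec-butyl on a carbonyl carbon gives, in this assay, a 100-fold lower number from compound 1 to compound 3 (2.00 log units; beyond the scatter). Among the compounds shown here, this is the first step whose size can be read, and it shows that the read-out responds strongly to the group at this place on the shared core. Measured against 1-methylbutyl, the same exchange gives an at least 5.7-fold lower number from compound 2 to compound 3 (0.75 log units; beyond the scatter), a step that has only a lower bound on its size: the limit of > 10000 nM in this assay, at which 1 of the 3 values shown sits.

Phenethyl brings an aromatic ring and more heavy atoms in a single change, and the compounds shown do not separate these two differences. Also open, on these data alone, is whether a benzyl group, a longer phenyl-bearing chain or a cyclohexylethyl group at this place would keep the number near that of compound 3.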